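A few compounds are considered here, and "the series" means these few. Any claim that something is new, unique, unknown or untested is made for them only; others in the source may bear on it.

Measured so far, in a functional assay on MCF7 cells (Homo sapiens) for inhibition, read by MTT assay, with a stated time of 72 h; a lower number here means a stronger inhibitor, a higher number a weaker inhibitor:
compound 1 `COc1cccc(/C=C/C(=O)Nc2cc(OC)c(OC)c(OC)c2)c1`, compound 1 gives 27000 nM
compound 2 `C=C(Br)C(=O)Nc1cccc(/C=C/C(=O)Nc2ccc(F)cc2)c1`, compound 2 gives 13600 nM

Within the data shown here, only two numbers exist in this assay and no step between them has been computed. Compound 2 sits at the smaller end of the two numbers, but the gap to compound 1 falls within the usual scatter of repeated measurements, so compound 2 is not set apart from compound 1 on these data. The two compounds also differ in more than one place, so nothing can be said about which part of either structure carries the difference.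

Compound 3 `C=C(Br)C(=O)Nc1cccc(/C=C/C(=O)NCc2ccc(C)cc2)c1` has not been measured. It differs from compound 2 in one place: 4-methylbenzyl in place of 4-fluorophenyl on an amide-type nitrogen. Among the measured compounds shown here, no measured pair shows what this kind of exchange does in this assay, so there is no step to lean on.

Without such a reference, the step expected from compound 2 to compound 3 is a 1.3-fold higher number from compound 2 to compound 3 (0.12 log units; within the scatter), that is, none beyond the scatter. Compound 3 is therefore estimated at 18000 nM, with a range from 5000 nM to 60000 nM.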

Compound 3, half-maximal inhibitory concentration: 2200 nM
For compound 3 the middle estimate is 8.2-fold (0.91 log units) above the measured one, and the stated range ends above it.
By their numbers in this assay, from the lowest: compound 3; then compounds 2 and 1 (each within the scatter of the next).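

In this assay, among these compounds, the amide-type nitrogen whose other neighbour is the carbonyl carbon is the first place where a single exchange gives a readable change: 4-methylbenzyl in place of 4-fluorophenyl gives a 6.2-fold lower number from compound 2 to compound 3 (0.79 log units; beyond the scatter) and so moves the number beyond the scatter. The group on this nitrogen therefore matters to the read-out, which compound 1 and compound 2 could not show; those two differ in more than one place and stand within the scatter of each other. Both groups count one six-membered aromatic ring of carbon only and no hydrogen-bond donors or acceptors, and no measurement at hand accounts for the step.

The compounds shown do not separate the extra carbon linking the ring to the nitrogen from the exchange of fluorine for methyl on the ring, and 4-fluorobenzyl and 4-methylphenyl would bear directly on that. Also open, on these data alone, is how the number responds on this nitrogen to a longer chain such as phenylethyl, or to a benzyl ring carrying an amine or a carboxylic acid.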